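Swapping the indazolyl for a substituted pyrazolyl

The source may report more compounds than this note shows. Statements on the series, on what has been measured and on what is new or still open speak of the compounds shown alone.

Within the data shown here, compound 2 `CCCC(Oc1ccc(-n2cc3ccccc3n2)cc1)c1ccc(C(=O)NCCC(=O)O)cc1` is the faster-cleared of the two compounds measured so far in an ADME assay on microsomes from liver (Homo sapiens) for metabolic stability (a lower number here means slower removal, a higher number faster removal of the compound), where compound 2 gives 44 mL/min/kg. Its nearest neighbour is compound 1 `CCCC(Oc1ccc(-n2cc(F)cn2)cc1)c1ccc(C(=O)NCCC(=O)O)cc1`, which in this assay gives 12 mL/min/kg; the one-point change between them, 4-fluoro-1H-pyrazol-1-yl to 2H-indazol-2-yl on an aromatic carbon, produced a 3.7-fold higher number from compound 1 to compound 2 (0.56 log units; beyond the scatter). Compound 3 `CCCC(Oc1ccc(-n2cc(C(F)(F)F)c(C)n2)cc1)c1ccc(C(=O)NCCC(=O)O)cc1` has not yet been measured. It differs from compound 2 as follows: 3-methyl-4-(trifluoromethyl)-1H-pyrazol-1-yl in place of 2H-indazol-2-yl on an aromatic carbon. Among the measured compounds shown here, the only measured step that bears on this change is the one from compound 1 to compound 2, which went up when a pyrazolyl gave way to the indazolyl; here the indazolyl leaves and a pyrazolyl, now carrying a methyl and a trifluoromethyl, returns. Compound 3 is therefore expected to show a 2.4-fold lower number from compound 2 to compound 3 (0.39 log units; beyond the scatter), a downward step in this assay. The estimate for compound 3 is 18 mL/min/kg, with a range from 9 mL/min/kg to 36 mL/min/kg.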

Compound 3, clearance in the Homo sapiens assay: < 10 mL/min/kg
Compound 3: no number, only a limit; the forecaster's own chance of this, stated with the estimate: 5%; middle value at least 1.8-fold (0.25 log units) away from the limit.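

In the Homo sapiens assay, compound 3 gives a limit of the assay and not a number: the limit of < 10 mL/min/kg in the Homo sapiens assay, at which 1 of the 3 values shown sits.

Even so, the result shows that a substituted pyrazolyl at this position can undo the rise seen with 2H-indazol-2-yl: in the Homo sapiens assay the change gives an at least 4.4-fold lower number from compound 2 to compound 3 (0.64 log units; beyond the scatter), while the comparison with the fluorinated pyrazolyl gives an at least 1.2-fold lower number from compound 1 to compound 3 (0.07 log units; that floor lies within the scatter), a floor that does not separate the two pyrazolyl compounds. In a physicochemical assay for lipophilicity, using the shake flask method, at pH 7.4 (a lower number here means a more polar compound, a higher number a more lipophilic compound), compound 2 gives 2.5 and compound 3 gives 2.8, a number 0.30 log units higher from compound 2 to compound 3 (within the scatter), so this pair shows the clearance step without a step beyond the scatter in that read-out.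

Going by these compounds, how far compound 3 lies from compound 1 stays open behind the limit. Also open, on these data alone, is whether the methyl or the trifluoromethyl carries the step, and how a pyrazolyl bearing a nitrile in place of the trifluoromethyl would behave.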